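The source may hold more compounds than are shown below. What is called first, only, known or untested is meant among the compounds shown, and "the series" means these compounds.

Two compounds share one core and differ only in the chain on the nitrogen. Compound 1 `CCCCCN(Cc1ccc(C(=O)NO)cc1)c1ncc(-c2ccc(C)cc2)s1` is measured in a functional assay on HCT-116 cells (Homo sapiens) for antiproliferative activity, read by MTT assay, with a stated time of 48 h (on this read-out higher numbers stand for weaker inhibition of growth and lower numbers for stronger inhibition of growth), at 23300 nM. Compound 2 `CCCCCCCCN(Cc1ccc(C(=O)NO)cc1)c1ncc(-c2ccc(C)cc2)s1` gives 6500 nM in this assay. Among the measured compounds shown here, the single step between them, a 3.6-fold lower number from compound 1 to compound 2 (0.55 log units; beyond the scatter), shows that lengthening the chain here went along with stronger growth inhibition. For the measured compounds named here, on these two numbers compound 2 stands lowest, with compound 1 as its only neighbour, a higher value beyond the scatter.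

Compound 3 `CCCCCCN(Cc1ccc(C(=O)NO)cc1)c1ncc(-c2ccc(C)cc2)s1` is a shorter chain than compound 2: hydrogen in place of ethyl on a saturated chain carbon, six bonds along the chain from a nitrogen on an aromatic ring. Ethyl leaves and hydrogen enters, on a saturated chain carbon six bonds along the chain from a nitrogen on an aromatic ring. Compound 3 thus sits between compound 1 and compound 2 in chain length. Going by the values given here, the only step that bears on it is the one from compound 1 to compound 2, so a shortening is expected to move the number back upward, toward compound 1, by a 2.3-fold higher number from compound 2 to compound 3 (0.36 log units; beyond the scatter) in this assay. Compound 3 is therefore estimated at 15000 nM, within a range from 7000 nM to 32000 nM.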

Compound 3, concentration for 50% growth inhibition: 4850 nM
The estimate for compound 3 lay 3.1-fold (0.49 log units) above the measured number; the whole stated range lies above it.
By their numbers in this assay, from the lowest: compounds 3 and 2 (each within the scatter of the next); then compound 1.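

In this assay there is a 1.3-fold lower number from compound 2 to compound 3 (0.13 log units; within the scatter), so the hexyl chain of compound 3 and the octyl chain of compound 2 cannot be told apart on this read-out. Against the pentyl chain of compound 1 there is a 4.8-fold lower number from compound 1 to compound 3 (0.68 log units; beyond the scatter), so among these three compounds the clear difference already appears with hexyl, and octyl adds nothing that can be distinguished from scatter; the number does not keep falling evenly as the chain grows. Nothing measured here explains why the chain behaves this way.

As far as these compounds go, it remains open whether a longer chain such as decyl or dodecyl would hold this level or lose it, and whether a shorter chain such as propyl would continue the rise in the number seen at pentyl. From the compounds shown here alone, it is also open how an amine or a carboxylic acid carried on the chain would compare with the plain hexyl chain of compound 3.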